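Aryl ether ketone series: working notes on metabolic stability

The source may hold more compounds than are shown below. What is called first, only, known or untested is meant among the compounds shown, and "the series" means these compounds.

Compound 1 `COC(=O)c1ccc(-c2nnn(CC(=O)C(C)Oc3ccc(Oc4ccc(Cl)cc4)cc3)n2)cc1` is the reference of the set. In an ADME assay on S9 fraction from liver (Rattus norvegicus) for metabolic stability, read by LC-MS, using NADPH, with a stated time of 30 min (on this read-out higher numbers stand for a more stable compound and lower numbers for a less stable compound), compound 1 gives < 5%, which is a limit of the assay and not a number (the limit of < 5% in this assay, at which 1 of the 3 values shown sits). Compound 2 `COC(=O)c1ccc(-c2nnn(CC(=O)C(C)Oc3ccc(Oc4ccc(C(F)(F)F)cc4)cc3)n2)cc1` differs from compound 1 by trifluoromethyl in place of chloro on an aromatic carbon; in this assay compound 2 gives 15%, and the step is a number at least 10 percentage points higher from compound 1 to compound 2 (that floor lies within the scatter). Compound 3 `CC(Oc1ccc(Oc2ccc(Cl)cc2)cc1)C(=O)Cn1nnc(-c2ccc(C(=O)O)cc2)n1` differs from compound 1 by hydrogen in place of methyl on an oxygen next to a carbonyl group; in this assay compound 3 gives 32%, the step being a number at least 27 percentage points higher from compound 1 to compound 3 (beyond the scatter). Of the two numbers shown, compound 3 stands above compound 2, a gap beyond the scatter.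

Compound 4 `CC(Oc1ccc(Oc2ccc(C(F)(F)F)cc2)cc1)C(=O)Cn1nnc(-c2ccc(C(=O)O)cc2)n1` is not yet measured. It differs from compound 3 by trifluoromethyl in place of chloro on an aromatic carbon, the same change as from compound 1 to compound 2, now on the core of compound 3. The expected step from compound 3 to compound 4 is a number 10 percentage points higher from compound 3 to compound 4 (within the scatter), set beside the measured a number at least 10 percentage points higher from compound 1 to compound 2 (that floor lies within the scatter), whose floor lies within the scatter, so the expectation is held loosely. Compound 4 is estimated at 42% in this assay, with an expected range from 25% to 60%.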

Compound 4, percent of the compound remaining: 36%
The estimate for compound 4 lay 6 percentage points above the measured number, within the range that was stated.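

In this assay, trifluoromethyl in place of chloro on the core of compound 3 gives a number 4 percentage points higher from compound 3 to compound 4 (within the scatter), and this step stands beside the one on the core of compound 1: the same change on two cores in this assay, a number at least 10 percentage points higher (that floor lies within the scatter) from compound 1 to compound 2 and a number 4 percentage points higher (within the scatter) from compound 3 to compound 4; the limit leaves it open whether they differ. Hydrogen in place of methyl on an oxygen next to a carbonyl group gives a number 21 percentage points higher from compound 2 to compound 4 (beyond the scatter), so this change raises the number beyond the scatter on both cores: the same change on two cores in this assay, a number at least 27 percentage points higher (beyond the scatter) from compound 1 to compound 3 and a number 21 percentage points higher (beyond the scatter) from compound 2 to compound 4; the limit leaves it open whether they differ. The value of compound 1 is a limit of the assay, so the pairs show a shared direction for the hydrogen change only, not that either change has the same size on both cores, and two cores set no rule for the series: the limit of < 5% in this assay, at which 1 of the 4 values shown sits.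

The compounds shown leave open how an amine or a nitrile would read in this assay at the place held by chloro and trifluoromethyl. They also leave open whether an amide in place of the carboxylic acid of compound 3 and compound 4 would hold the number.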